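A few compounds are considered here, and "the series" means these few. Any claim that something is new, unique, unknown or untested is made for them only; others in the source may bear on it.

Measured so far:
- compound 1 `N#Cc1c(-c2ccccc2)cn(-c2ccc(S(=O)(=O)Nc3nccs3)cc2)c1N`: 5360 nM
- compound 2 `N#Cc1c(-c2ccccc2)cn(-c2ccc(S(=O)(=O)Nc3ccccn3)cc2)c1N`: 5300 nM
- compound 3 `O=c1[nH]cnc2c1c(-c1ccccc1)cn2-c1ccc(S(=O)(=O)Nc2nccs2)cc1`: 5300 nM

In a functional assay on HepG2 cells (Homo sapiens) for inhibition, read by sulforhodamine B assay, with a stated time of 24 h (on this read-out higher numbers stand for weaker inhibition and lower numbers for stronger inhibition), compound 1 gives 5360 nM, the highest of the three numbers, although its gaps to compound 2 and compound 3 both lie within the scatter. For the measured compounds named here, the one single-point step recorded, a 1.0-fold lower number from compound 1 to compound 2 (0.00 log units; within the scatter), concerns the sulfonamide nitrogen and not the amino group. Compound 4 `N#Cc1c(-c2ccccc2)cn(-c2ccc(S(=O)(=O)Nc3nccs3)cc2)c1NC(=O)CCC(=O)O` differs from compound 1 by (2-carboxyethyl)carbonyl in place of hydrogen on a nitrogen on an aromatic ring. Going by the values given here, no measured pair touches this nitrogen, so the expectation rests on the flat numbers alone. Compound 4 is expected to stay close to compound 1, with the step of a 1.1-fold higher number from compound 1 to compound 4 (0.05 log units; within the scatter) not beyond the scatter. The estimated value for compound 4 is 6000 nM, between 2000 nM and 18000 nM.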

Compound 4, half-maximal inhibitory concentration: 3750 nM
Estimate against measurement, compound 4: 1.6-fold (0.20 log units) above; low and high end bracket the measured number.
By their numbers in this assay, from the lowest: compounds 4, 2, 3 and 1 (each within the scatter of the next).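

For the compounds shown here, this is the first measured change at the amino group of compound 1: with (2-carboxyethyl)carbonyl in place of hydrogen on this nitrogen, this assay gives a 1.4-fold lower number from compound 1 to compound 4 (0.16 log units; within the scatter). A chain of this size, ending in a carboxylic acid, is therefore accepted here without a step beyond the scatter. No measurement at hand accounts for this result.

The compounds shown leave open whether a plain acetyl group, a methyl ester of this chain or a longer chain ending in a carboxylic acid on this nitrogen would read any differently. They also leave open whether (2-carboxyethyl)carbonyl gives the same picture on compound 2.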